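This account rests on a few compounds, and the source may have more. Where it says the series, first, only, none or still open, it means among the compounds named here.

Measured so far:
Compound 1 `N[C@H]1CC[C@H](Nc2c(C(=O)NCc3ccco3)nc(Br)c3cccnc23)CC1` in a functional assay on HCT-116 cells (Homo sapiens) for cytotoxicity, read by MTT assay, with a stated time of 72 h (on this read-out lower numbers stand for stronger inhibition and higher numbers for weaker inhibition), gives > 10000 nM, which is a limit of the assay and not a number.
Compound 2 `C[C@@H](Nc1c(C(=O)NCc2ccc(F)cc2)nc(Br)c2cccnc12)c1ccccc1` gives > 20000 nM, likewise a limit rather than a number.
Compound 3 `C[C@@H](CO)Nc1nc(C(=O)NCc2ccc(F)cc2)c(O)c2ncccc12` in this assay gives "not determined" (no result reported), that is, no reported result.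

Compound 2 therefore stands where the shown numbers run out: its result is a limit (the limit of > 20000 nM in this assay, at which 1 of the 3 values shown sits). The result for compound 1 is also a limit (the limit of > 10000 nM in this assay, at which 1 of the 3 values shown sits), and compound 3 adds no value at all. Among the compounds with values here, no two measured compounds differ in only one place, so no measured step can be drawn among them. The compound still to be measured is compound 4 `Cc1ccc(S(=O)(=O)Oc2c(C(=O)NCc3ccc(F)cc3)nc(Br)c3cccnc23)cc1`. Compared with compound 2 it carries ((4-methylphenyl)sulfonyl)oxy in place of (1-phenylethyl)amino on an aromatic carbon.

Within the data shown here, with no measured step to lean on, the expectation in this assay rests only on compound 2 sitting at a limit (the limit of > 20000 nM in this assay, at which 1 of the 3 values shown sits). The step from compound 2 to compound 4 is expected to be none beyond the scatter, a step that the limit leaves unreadable from compound 2 to compound 4. Compound 4 is thus estimated at 30000 nM, within 5000 nM to 100000 nM, most likely reported again only as a limit.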

Compound 4, half-maximal inhibitory concentration: > 20000 nM
Compound 4 was reported as a limit (the forecaster's own chance of this, stated with the estimate: 80%); the middle value is on the limit's open side.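

Compound 2 and compound 4 are both reported only as limits and not as numbers, so no step can be read between them. The compounds shown leave open how ((4-methylphenyl)sulfonyl)oxy in place of (1-phenylethyl)amino affects the result in this assay.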